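The source may report more compounds than this note shows. Statements on the series, on what has been measured and on what is new or still open speak of the compounds shown alone.

Measured so far in a physicochemical assay for solubility, in phosphate buffer, at pH 7.4; a lower number here means a less soluble compound, a higher number a more soluble compound:
- compound 1 `CCn1cc(C(=O)C(=O)Nc2ccc(OC)nc2)c2ccccc21` gives 10000 nM
- compound 2 `COCC(C)n1cc(C(=O)C(=O)Nc2ccc(OC)nc2)c2ccccc21` gives 40000 nM

Compound 2 holds the higher of these two numbers. Within the data shown here, the only measured step is a 4.0-fold higher number from compound 1 to compound 2 (0.60 log units; beyond the scatter), which is beyond the scatter and comes with methoxymethyl in place of hydrogen on a saturated chain carbon bound to an aromatic nitrogen and a saturated chain carbon.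

The next compound is compound 3 `COCC(C)(C)n1cc(C(=O)C(=O)Nc2ccc(OC)nc2)c2ccccc21`, and the change is methyl in place of hydrogen on a saturated chain carbon bound to an aromatic nitrogen and two saturated chain carbons. This takes 1-(methoxymethyl)ethyl to 1-(methoxymethyl)-1-methylethyl. The measured step bears on this only loosely, since it lies in the same part of the structure but involves methoxymethyl, not methyl. Among the measured compounds shown here, no measured step shows what methyl does here.

A shift smaller than a 4.0-fold higher number from compound 1 to compound 2 (0.60 log units; beyond the scatter) is therefore expected in this assay, most likely within the scatter, with a slight lean towards a lower number and the direction left open. The expected change is a 1.1-fold lower number from compound 2 to compound 3 (0.06 log units; within the scatter). Compound 3 is estimated at 35000 nM, with an expected range of 12000 nM to 90000 nM.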

Compound 3, solubility: 10000 nM
The estimate for compound 3 lay 3.5-fold (0.54 log units) above the measured number; the measured number lies below the stated range.
By their numbers in this assay, from the lowest: compounds 1 and 3 (each within the scatter of the next); then compound 2.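

Working notes: in this assay the saturated chain carbon bound to an aromatic nitrogen and two saturated chain carbons does not tolerate a further methyl without consequence: the read-out shows a 4.0-fold lower number from compound 2 to compound 3 (0.60 log units; beyond the scatter) for this single added carbon. That step matches the earlier 4.0-fold higher number from compound 1 to compound 2 (0.60 log units; beyond the scatter) in size and runs opposite to it, and the wider replacement of ethyl by 1-(methoxymethyl)-1-methylethyl gives no change at the digits printed from compound 1 to compound 3 (within the scatter) in the same assay. Methoxymethyl therefore does not go with a higher number in every setting shown: the higher number belongs to 1-(methoxymethyl)ethyl in compound 2 and not to 1-(methoxymethyl)-1-methylethyl in compound 3. Nothing available accounts for this reversal.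

Still open, from the compounds shown here alone, is whether the added methyl would do the same without methoxymethyl, a question that an isopropyl or tert-butyl group on the aromatic nitrogen would address. Also open, going by these compounds, is how the read-out would respond at this position to a longer ether chain such as 2-methoxyethyl, or to an amine such as dimethylaminomethyl in place of methoxymethyl.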